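Benzyl in place of acid hydrogen on a proline amide

The source may report more compounds than this note shows. Statements on the series, on what has been measured and on what is new or still open speak of the compounds shown alone.

Measured compounds:
compound 1 `O=C(O)[C@@H]1CCCN1C(=O)CN(c1nc(Cl)nc2[nH]cnc12)C1CC1` with 7.29%
compound 2 `O=C(CN(c1ncnc2c1ncn2C1CCCCO1)C1CC1)NCC(=O)OCc1ccccc1` with 7.26%

The account concerns two measured compounds and one that has not yet been measured. In a functional assay on the whole organism (Tail, strain ICR) with Mus musculus as the target, in the tail flick test, with a stated time of 150 min, at a dose of 25 umol/kg by the oral route (on this read-out higher numbers stand for a stronger effect at the one dose given and lower numbers for a weaker effect), compound 1 gives 7.29%. Compound 2, which carries a different core and a benzyl group on its own terminal oxygen, gives 7.26% in this assay. Compound 1 has the higher of the two numbers, but the two values lie within the scatter of each other, so no order between them can be read from this assay.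

Compound 3 `O=C(OCc1ccccc1)[C@@H]1CCCN1C(=O)CN(c1nc(Cl)nc2[nH]cnc12)C1CC1` is derived from compound 1 by a single change: benzyl in place of hydrogen on an oxygen next to a carbonyl group. Among the compounds with values here, no step between measured compounds of this kind is available, so the size of the step has to be judged from what the two measured compounds show. Since both compound 1 and compound 2 sit at low values, a step from compound 1 to compound 3 that stays within the scatter is expected, and compound 3 is estimated to give 8% in this assay, with a range from 0% to 25%, corresponding to an expected step of a number 0.7 percentage points higher from compound 1 to compound 3 (within the scatter).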

Compound 3, a percentage reported as activity, at one dose (the size of the read-out at that dose, not a potency): 31.1%
The estimate for compound 3 lay 23.1 percentage points below the measured number; measured number outside the range, above it.
By their numbers in this assay, from the lowest: compounds 2 and 1 (each within the scatter of the next); then compound 3.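

In this assay, the terminal position of compound 1 proves responsive: benzyl in place of hydrogen on an oxygen next to a carbonyl group gives a number 23.8 percentage points higher from compound 1 to compound 3 (beyond the scatter), with the core of compound 1 left unchanged, so this number is not a floor set by that core alone. Compound 2 also carries a benzyl group on a terminal oxygen, but it differs from compound 3 in more than one place, so its number says nothing about the size of this step and the step stands as a single observation on one core. The data shown offer no measurement that would explain why carboxy to benzyloxycarbonyl moves the number in this way.

Going by these compounds, it remains open whether the benzyl group itself matters or whether a methyl or ethyl group on the same oxygen would give a similar number. Also unresolved is how a phenethyl group on that oxygen, or a primary amide in place of the carboxylic acid of compound 1, would compare.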